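Lengthening the alkyne chain on an adenosine analogue

A few compounds are considered here, and "the series" means these few. Any claim that something is new, unique, unknown or untested is made for them only; others in the source may bear on it.

Measured so far:
compound 1 `C#CCN(CC[C@H](N)C(=O)O)C[C@H]1O[C@@H](n2cnc3c(N)ncnc32)[C@H](O)[C@@H]1O` — 72.2%
compound 2 `CC#CCN(CC[C@H](N)C(=O)O)C[C@H]1O[C@@H](n2cnc3c(N)ncnc32)[C@H](O)[C@@H]1O` — 61.3%

Compound 1 and compound 2 share a common core and differ only at a triple-bonded carbon. In an assay for inhibition of tRNA (cytosine(38)-C(5))-methyltransferase (Homo sapiens), read by scintillation counting, tested at 100 uM (a lower number here means less inhibition, a higher number more inhibition at the concentration tested (going by the name of the read-out)), compound 1 gives 72.2%, and compound 2 gives 61.3%, the lower of the two numbers; the step of a number 10.9 percentage points lower from compound 1 to compound 2 (beyond the scatter), a methyl in place of hydrogen on a triple-bonded carbon, lowered inhibition modestly.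

Compound 3 `CCC#CCN(CC[C@H](N)C(=O)O)C[C@H]1O[C@@H](n2cnc3c(N)ncnc32)[C@H](O)[C@@H]1O` has not yet been tested. It differs from compound 2 by methyl in place of hydrogen on a saturated chain carbon bound to a triple-bonded carbon. Within the data shown here, the only step that bears on this change is a number 10.9 percentage points lower from compound 1 to compound 2 (beyond the scatter), a modest loss on growing the same chain by one carbon. A further carbon on that chain is therefore expected to give a small loss again, or none beyond the scatter, as a number 8.3 percentage points lower from compound 2 to compound 3 (within the scatter). Compound 3 is estimated at 53% in this assay, within 38% to 66%.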

Compound 3, a percentage reported as inhibition, at one concentration (the size of the read-out at that concentration, not a potency): 62.8%
Compound 3: the middle estimate sits 9.8 percentage points below what was measured; measured number inside the range.
By their numbers in this assay, from the lowest: compounds 2, 3 and 1 (each within the scatter of the next, the first and the last beyond it).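

In this assay, going from but-2-yn-1-yl to pent-2-yn-1-yl, a methyl in place of hydrogen on a saturated chain carbon bound to a triple-bonded carbon, gives a number 1.5 percentage points higher from compound 2 to compound 3 (within the scatter) and so makes no readable difference at this position. Swapping hydrogen for ethyl at the triple-bonded carbon gives a number 9.4 percentage points lower from compound 1 to compound 3 (within the scatter) in the same assay, so ethyl cannot be told apart from hydrogen here, whereas the step from hydrogen to methyl lies beyond the scatter, and the three compounds show no steady fall in inhibition as the chain grows. Nothing available explains these numbers.

Still open, going by these compounds, is whether a longer chain on the triple-bonded carbon, or a chain ending in an amine or a carboxylic acid, would keep inhibition at this level. Each number comes from a single concentration, so how the potencies of these compounds compare also remains open.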